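Silyl capping of the primary alcohol in compound 1

This account rests on a few compounds, and the source may have more. Where it says the series, first, only, none or still open, it means among the compounds named here.

Compound 1 `C=C1CC[C@@H]2[C@](C)(CO)[C@H](OC(C)=O)CC[C@@]2(C)[C@@H]1C/C=C1/C(=O)OC[C@H]1O` carries a free primary alcohol and a free ring alcohol on the lactone side. In a functional assay on P388 cells (Mus musculus) for cytotoxicity, read by sulforhodamine B assay (a higher number here means that more compound is needed for the effect, a lower number that less compound is needed), compound 1 gives 4.78 uM, the highest of the three numbers in hand. Compound 2 `C=C1CC[C@@H]2[C@](C)(CO)[C@H](OC(C)=O)CC[C@@]2(C)[C@@H]1C/C=C1/C(=O)OC[C@H]1OC(C)=O` gives 0.69 uM, and the change from a 6.9-fold lower number from compound 1 to compound 2 (0.84 log units; beyond the scatter) is an acetyl in place of hydrogen on an oxygen on a saturated carbon. Compound 3 `C=C1CC[C@@H]2[C@](C)(CO[Si](c3ccccc3)(c3ccccc3)C(C)(C)C)[C@H](O)CC[C@@]2(C)[C@@H]1C/C=C1/C(=O)OC[C@H]1O` gives 0.68 uM; it differs from compound 1 in more than one place, so its value is read only as a second case in which capping the primary alcohol accompanies a lower number.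

Compound 4 `C=C1CC[C@@H]2[C@](C)(CO[Si](C)(C)C(C)(C)C)[C@H](OC(C)=O)CC[C@@]2(C)[C@@H]1C/C=C1/C(=O)OC[C@H]1O` differs from compound 1 by a group of 7 heavy atoms (6 carbon, 1 silicon; no ring) in place of a hydrogen atom, on an oxygen on a saturated carbon. The single-site step that bears on it, the capping of an oxygen in compound 2, moved the number down beyond the scatter, and compound 3 with a silyl group on the same oxygen sits at the low end too. A step in the same direction, of a similar size, is therefore expected for compound 4 in this assay, a 5.3-fold lower number from compound 1 to compound 4 (0.73 log units; beyond the scatter). Compound 4 is estimated at 0.9 uM, with a range of 0.3 uM to 2.5 uM.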

Compound 4, concentration for half-maximal effect: 1.71 uM
Compound 4: the middle estimate sits 1.9-fold (0.28 log units) below what was measured; low and high end bracket the measured number.
By their numbers in this assay, from the lowest: compounds 3 and 2 (each within the scatter of the next); then compound 4; then compound 1.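

In this assay, the primary alcohol of compound 1 now has a single-place reading of its own: a group of 7 heavy atoms (6 carbon, 1 silicon; no ring) in place of the hydrogen on that oxygen gives a 2.8-fold lower number from compound 1 to compound 4 (0.45 log units; beyond the scatter). The free hydrogen on this oxygen is therefore not required for the effect in compound 4, and capping the primary alcohol moves the number the same way as acetyl on the ring alcohol, a 6.9-fold lower number from compound 1 to compound 2 (0.84 log units; beyond the scatter). Nothing in the data gives a reason for either step.

From the compounds shown here alone, whether the silicon group itself matters at this oxygen, or any cap would do, stays open, since an acetyl or a methyl ether there would separate the two readings. Also open, going by these compounds, is how a longer carbon chain or an amine at this position would read.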